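Adding a Second Fluorine to a Weak Antiproliferative Amide

The source may hold more compounds than are shown below. What is called first, only, known or untested is meant among the compounds shown, and "the series" means these compounds.

Two compounds share one core and differ only in the group on the amine nitrogen in a ring. Compound 1 `CN1CCN(c2ccc(-c3cc4c(N5CCN(S(=O)(=O)C6CC6)CC5)ncnc4s3)cc2)CC1` carries a cyclopropylsulfonyl there; in a functional assay on MDA-MB-231 cells (Homo sapiens) for antiproliferative activity, read by MTT assay, with a stated time of 48 h (on this read-out higher numbers stand for weaker inhibition and lower numbers for stronger inhibition), compound 1 gives 11500 nM. Compound 2 `CN1CCN(c2ccc(-c3cc4c(N5CCN(C(=O)Nc6ccccc6F)CC5)ncnc4s3)cc2)CC1` carries a (2-fluorophenyl)carbamoyl instead, and in this assay compound 2 gives 10300 nM. Compound 2 has the lowest of the two numbers, but the step of a 1.1-fold lower number from compound 1 to compound 2 (0.05 log units; within the scatter) is within the scatter, so the two compounds cannot be told apart on these data.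

Compound 3 `CN1CCN(c2ccc(-c3cc4c(N5CCN(C(=O)Nc6ccc(F)cc6F)CC5)ncnc4s3)cc2)CC1` is the next step. The change from compound 2 to compound 3 is fluoro in place of hydrogen on an aromatic carbon. For the measured compounds named here, no measured step touches this change directly; the only step at hand, a 1.1-fold lower number from compound 1 to compound 2 (0.05 log units; within the scatter), swapped the whole group on the ring nitrogen and moved the number within the scatter. Nothing here therefore points to a step beyond the scatter in this assay in either direction.

Compound 3 is thus expected to give about 10000 nM, with a range from 5000 nM to 20000 nM, an expected step of a 1.0-fold lower number from compound 2 to compound 3 (0.01 log units; within the scatter).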

Compound 3, half-maximal inhibitory concentration: 11400 nM
For compound 3 the middle estimate is 1.1-fold (0.06 log units) below the measured one; measured number inside the range.
By their numbers in this assay, from the lowest: compounds 2, 3 and 1 (each within the scatter of the next).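

In this assay the fluoro added to the aromatic carbon, para to a large group and meta to the existing fluoro group, gives a 1.1-fold higher number from compound 2 to compound 3 (0.04 log units; within the scatter) and so leaves 2-fluorophenyl and 2,4-difluorophenyl indistinguishable on this read-out. Set against the cyclopropylsulfonyl on the ring nitrogen, the (2,4-difluorophenyl)carbamoyl gives a 1.0-fold lower number from compound 1 to compound 3 (0.00 log units; within the scatter) and so adds a second carbamoyl compound that cannot be separated from compound 1, which places all three compounds within the scatter of one another. No other measurement accompanies these numbers, so nothing here offers an explanation for how little they differ.

On these data alone, with no step beyond the scatter so far, it remains open whether any change at this aromatic carbon can move the number at all, for instance an amine or a carboxylic acid in place of the fluoro. As far as these compounds go, it is equally open whether replacing the whole difluorophenyl with a longer chain, or with a basic amine on the carbamoyl, would separate a compound from these three.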